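The source may hold more compounds than are shown below. What is called first, only, known or untested is meant among the compounds shown, and "the series" means these compounds.

In an ADME assay on HEK293 cells (Homo sapiens) for cytotoxicity, read by MTT assay, with a stated time of 48 h (a higher number here means a weaker inhibitor, a lower number a stronger inhibitor), the measured compounds read:

compound 1 `CCN(CC)CCCCn1c(N)c(-c2nc3ccccc3n2C)c2nc(C#N)c(C#N)nc21`: 3160 nM
compound 2 `CN(C)CCn1c(N)c(-c2nc3cc(Cl)ccc3[nH]2)c2nc(C#N)c(C#N)nc21`: > 50000 nM (a limit of the assay, not a number)
compound 3 `CN(C)CCCn1c(N)c(-c2nc3cc(Cl)ccc3[nH]2)c2nc(C#N)c(C#N)nc21`: 11700 nM

Of the two actual numbers, compound 3 holds the higher at 11700 nM, and compound 1 sits lower at 3160 nM, a gap beyond the usual scatter. Compared with compound 3, compound 4 `CCN(CC)CCCCn1c(N)c(-c2nc3cc(Cl)ccc3[nH]2)c2nc(C#N)c(C#N)nc21` carries (diethylamino)methyl in place of dimethylamino on a saturated chain carbon, three bonds along the chain from an aromatic nitrogen. For the measured compounds named here, the one measured step that bears on this is an at least 4.2-fold lower number from compound 2 to compound 3 (0.63 log units; beyond the scatter), also a lengthening of the chain. The 4-(diethylamino)butyl chain of compound 4 also stands on compound 1, which gives 3160 nM, though the rest of that molecule differs. A modest move to a lower number is therefore expected, an estimated 2.9-fold lower number from compound 3 to compound 4 (0.47 log units; beyond the scatter). Compound 4 is expected near 4000 nM, with an estimated range of 1500 nM to 10000 nM.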

Compound 4, half-maximal inhibitory concentration: 3860 nM
Estimate against measurement, compound 4: 1.0-fold (0.02 log units) above, within the range that was stated.
By their numbers in this assay, from the lowest: compounds 1 and 4 (each within the scatter of the next); then compound 3. At a limit, above all of these: compound 2.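

In this assay, 4-(diethylamino)butyl in place of 3-(dimethylamino)propyl gives a 3.0-fold lower number from compound 3 to compound 4 (0.48 log units; beyond the scatter), so the number moves lower again as the chain grows. With that chain held, 5-chloro-1H-benzimidazol-2-yl in place of 1-methyl-1H-benzimidazol-2-yl gives a 1.2-fold higher number from compound 1 to compound 4 (0.09 log units; within the scatter), so the swap shows no real change. The widest step, an at least 12-fold lower number from compound 2 to compound 4 (1.11 log units; beyond the scatter), starts from a limit and gives only a bound: the limit of > 50000 nM in this assay, at which 1 of the 4 values shown sits.

Chain length and the ethyl groups on the amine changed together, so their shares remain unknown. From the compounds shown here alone, a 4-(dimethylamino)butyl chain would separate them, and a piperidine ring at the chain end remains open.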